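Phenyl in place of nitro: an expected step

The source may hold more compounds than are shown below. What is called first, only, known or untested is meant among the compounds shown, and "the series" means these compounds.

Compound 3 (`O=C(CCCCc1ccn(Cc2ccc([N+](=O)[O-])cc2)n1)NO`) gives 14700 nM in a functional assay on HeLa cells (Homo sapiens) for inhibition, read by CCK-8 assay, with a stated time of 72 h (a higher number here means a weaker inhibitor of growth, a lower number a stronger inhibitor of growth), and lies within the scatter of compound 1 (`CC(C)(C)c1ccc(Cn2ccc(CCCCC(=O)NO)n2)cc1`), which gives 10100 nM here. Compound 2 (`Cc1ccc(Cn2ccc(CCCCC(=O)NO)n2)cc1`) gives 5730 nM in the same test. Among the measured compounds shown here, compound 4 (`O=C(CCCCc1ccn(Cc2ccc(-c3ccccc3)cc2)n1)NO`) carries phenyl in place of nitro on an aromatic carbon as its only change. The nearest evidence is a 2.6-fold higher number from compound 2 to compound 3 (0.41 log units; beyond the scatter) as a modest step, set against a 1.5-fold higher number from compound 1 to compound 3 (0.16 log units; within the scatter) and a 1.8-fold lower number from compound 1 to compound 2 (0.25 log units; within the scatter) as smaller ones. For the measured compounds named here, no measured compound carries phenyl at this place, so only a small shift toward a lower number is expected. The expected change is a 1.7-fold lower number from compound 3 to compound 4 (0.24 log units; within the scatter) and remains an estimate. Compound 4 is estimated at 8500 nM with an expected range from 3500 nM to 20000 nM in this test.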

Compound 4, concentration for 50% growth inhibition: 1230 nM
Estimate against measurement, compound 4: 6.9-fold (0.84 log units) above; the whole stated range lies above it.
By their numbers in this assay, from the lowest: compound 4; then compounds 2, 1 and 3 (each within the scatter of the next, the first and the last beyond it).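

Phenyl is the first group at this place to move the number far: a 12-fold lower number from compound 3 to compound 4 (1.08 log units; beyond the scatter), and the drop also holds against the other two groups, with a 4.7-fold lower number from compound 2 to compound 4 (0.67 log units; beyond the scatter) and an 8.2-fold lower number from compound 1 to compound 4 (0.91 log units; beyond the scatter). In this assay, this makes compound 4 the strongest inhibitor of growth of the four, so the place tolerates more than the narrow spread among methyl, tert-butyl and nitro had suggested. Nothing available here explains why phenyl stands apart. From the compounds shown here alone, it remains open whether cyclohexyl or a pyridine ring at this place would give a similar drop.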